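This account rests on a few compounds, and the source may have more. Where it says the series, first, only, none or still open, it means among the compounds named here.

Compound 1, `C=C(C)C(=O)c1ccc(CCCCCCC)cc1`, gives 52900 nM in an assay on isolated protein for displacement of a labelled ligand from thyroid hormone receptor alpha (Homo sapiens), read by fluorescence polarization; on this read-out higher numbers stand for weaker inhibition and lower numbers for stronger inhibition.
Compound 2, `C=CC(=O)c1ccc(CCCC)cc1`, gives 71000 nM in this assay.

Within the data shown here, compound 2 stands at the highest of the two numbers, but its only neighbour, compound 1, lies within the scatter of it, so the two values read as alike rather than as different. Both are high numbers, which on this read-out stand for weak inhibition. Compound 3, `C=CC(=O)c1ccc(CC(C)(C)C)cc1`, has not been measured yet. It differs from compound 2 by tert-butyl in place of propyl on a saturated chain carbon bound to an aromatic carbon. Among the measured compounds shown here, no step between measured compounds is known, so the data give no foothold for the direction of this change. With nothing to point either way, compound 3 is expected to stay close to compound 2. The expected step of a 1.1-fold lower number from compound 2 to compound 3 (0.04 log units; within the scatter) is therefore none beyond the scatter. Compound 3 is expected to give about 65000 nM in this assay, within a range from 20000 nM to 200000 nM.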

Compound 3, half-maximal inhibitory concentration: 69600 nM
Compound 3: the middle estimate sits 1.1-fold (0.03 log units) below what was measured; the measured number falls inside the stated range.
By their numbers in this assay, from the lowest: compounds 1, 3 and 2 (each within the scatter of the next).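

Tert-butyl in place of propyl on a saturated chain carbon bound to an aromatic carbon gives a 1.0-fold lower number from compound 2 to compound 3 (0.01 log units; within the scatter) in this assay, the first step that can be read at this position. A branched group and a straight one therefore read as alike here, and both compounds remain at high numbers, which stand for weak inhibition. No measurement at hand explains why the two groups read as alike.

Both groups in this step are built only of carbon and hydrogen, so the compounds shown leave open whether an amine or a carboxylic acid in this place would give a clearly different number. They also leave open whether a longer chain on the shared core of compound 2, with nothing else altered, would stay equally close.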